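The compounds below may be only part of what the source reports. "The series", "measured", "known", "first", "only" and "open" are said of these compounds alone.

Measured in an ADME assay on MDCK cells (Canis lupus familiaris) for cytotoxicity, read by MTT assay, with a stated time of 24 h; a lower number here means that less compound is tolerated, a higher number that more compound is tolerated:
- compound 1 `O=S(=O)(c1ccc(Br)cc1)N(Cc1cccs1)Cc1cccs1`: 81000 nM
- compound 2 `CCCN(Cc1cccs1)S(=O)(=O)c1ccc(Br)cc1`: > 178000 nM

For compound 2 the reading > 178000 nM is a limit of this assay, not a number (the limit of > 178000 nM in this assay, at which 1 of the 2 values shown sits).

Compound 3 `CCOC(=O)CCN(Cc1cccs1)S(=O)(=O)c1ccc(Br)cc1` carries ethoxycarbonyl in place of methyl on a saturated chain carbon, two bonds along the chain from a sulfonamide nitrogen.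

Going by the values given here, the only measured guide is an at least 2.1-fold higher number from compound 1 to compound 2 (0.34 log units; beyond the scatter), with ethyl in place of thiophen-2-yl. This is a different exchange, so it bears only loosely. Still, it suggests that swapping in a bigger group than ethyl may lower the number modestly.

The expected step is an at least 1.2-fold lower number from compound 2 to compound 3 (0.10 log units; that floor lies within the scatter). Compound 3 is estimated at 140000 nM, with an expected range of 60000 nM to 320000 nM.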

Compound 3, half-maximal cytotoxic concentration: > 154000 nM
Compound 3: no number, only a limit; the forecaster's own chance of this, stated with the estimate: 45%; middle value at least 1.1-fold (0.04 log units) away from the limit.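

In this assay compound 3 reads > 154000 nM and this is a limit of the assay, not a number. Compound 2 also stands at a limit, so the step between the two cannot be read. Even so, ethoxycarbonyl at this place on the chain brings no measurable fall in the number, and the comparison with the thiophen-2-yl group gives an at least 1.9-fold higher number from compound 1 to compound 3 (0.27 log units; that floor lies within the scatter) with a floor that lies within the scatter.

From the compounds shown here alone, how far compound 2 and compound 3 truly lie apart stays open. So does whether a carboxylic acid or an amine at this place would give a readable number.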